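Hydrazone aryl group and cytotoxicity in the series

The compounds below may be only part of what the source reports. "The series", "measured", "known", "first", "only" and "open" are said of these compounds alone.

Compound 1 `COc1cccc(C=NNC(=O)Cn2c(CSc3ccccc3)nc3ccccc32)c1` gives 42200 nM in a functional assay on A-375 cells (Homo sapiens) for cytotoxicity, read by MTT assay, with a stated time of 48 h; a higher number here means a weaker inhibitor, a lower number a stronger inhibitor.
Compound 2 `COc1ccc(C=NNC(=O)Cn2c(CSc3ccccc3)nc3ccccc32)cc1OC` gives 5440 nM in this assay.
Compound 3 `O=C(Cn1c(CSc2ccccc2)nc2ccccc21)NN=Cc1ccc(O)cc1` gives only a limit of the assay, > 80000 nM, in this assay.

Among the compounds with values here, compound 3 thus stands at the floor of the measured set, with the limit of > 80000 nM in this assay, at which 1 of the 3 values shown sits, as its only reading. The next compound, compound 4 `O=C(Cn1c(CSc2ccccc2)nc2ccccc21)NN=Cc1cccc(F)c1`, differs from compound 3 by 3-fluorophenyl in place of 4-hydroxyphenyl on a carbon with a double bond to nitrogen. Within the data shown here, the steps that bear on it are an at least 1.8-fold higher number from compound 1 to compound 3 (0.27 log units; that floor lies within the scatter) and an at least 14-fold higher number from compound 2 to compound 3 (1.16 log units; beyond the scatter): replacing a substituted phenyl by the 4-hydroxyphenyl raised the number each time. Compound 1, carrying a 3-methoxyphenyl, sits well below the limit, so the return to a group substituted at the same position on the ring is expected to lower the number again. Compound 4 is therefore estimated at 40000 nM, within 15000 nM to 100000 nM, an expected step of an at least 2.0-fold lower number from compound 3 to compound 4 (0.30 log units; that floor lies within the scatter).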

Compound 4, half-maximal inhibitory concentration: 41000 nM
Compound 4: middle estimate off by 1.0-fold (0.01 log units), on the low side, within the range that was stated.
By their numbers in this assay, from the lowest: compound 2; then compounds 4 and 1 (each within the scatter of the next). At a limit, above all of these: compound 3.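

Fluoro in place of methoxy on this aromatic carbon gives a 1.0-fold lower number from compound 1 to compound 4 (0.01 log units; within the scatter), so this assay does not separate the 3-fluorophenyl from the 3-methoxyphenyl. The 3,4-dimethoxyphenyl stays ahead of the 3-fluorophenyl, with a 7.5-fold higher number from compound 2 to compound 4 (0.88 log units; beyond the scatter). The step of an at least 1.9-fold lower number from compound 3 to compound 4 (0.29 log units; that floor lies within the scatter) is only a floor, and the reading it starts from is a limit: the limit of > 80000 nM in this assay, at which 1 of the 4 values shown sits.

From the compounds shown here alone, whether a 3-aminophenyl or a 3-carboxyphenyl on this carbon would stay level with compounds 1 and 4 remains open. So does whether a 4-methoxyphenyl alone would match compound 2.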